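Pyrazole chalcones: methoxy additions and cytotoxicity

The compounds below may be only part of what the source reports. "The series", "measured", "known", "first", "only" and "open" are said of these compounds alone.

Measured compounds:
compound 1 `COc1ccc(-c2cc(/C=C/C(=O)c3ccc(N)cc3)[nH]n2)cc1` — 95%
compound 2 `COc1ccc(C(=O)/C=C/c2cc(-c3cc(OC)c(OC)c(OC)c3)n[nH]2)cc1OC` — 94%
compound 3 `COc1ccc(-c2cc(/C=C/C(=O)c3ccc(N)cc3)[nH]n2)cc1OC` — 95%

In a functional assay on 786-0 cells (Homo sapiens) for cytotoxicity, read by sulforhodamine B assay, with a stated time of 48 h, tested at 0.1 uM (on this read-out lower numbers stand for a stronger effect and higher numbers for a weaker effect at the one concentration tested), compound 1 gives 95% and compound 3 gives 95%. The two differ by methoxy in place of hydrogen on an aromatic carbon, and the step of no change at the digits printed from compound 1 to compound 3 (within the scatter) is within the scatter. Compound 2, on the other core, gives 94% in this assay; all three numbers lie within the scatter of one another, so no order among them is read. The difference between the core of compound 1 and the core of compound 2 is not broken down here.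

Compound 4 `COc1cc(C(=O)/C=C/c2cc(-c3cc(OC)c(OC)c(OC)c3)n[nH]2)cc(OC)c1OC` has not yet been measured in this assay. It relates to compound 2 by methoxy in place of hydrogen on an aromatic carbon, the same kind of change as from compound 1 to compound 3, though here the entering group is also meta to a methoxy group, which is not so in compound 3. Because no change at the digits printed from compound 1 to compound 3 (within the scatter) showed no change at the digits printed, a comparably flat step is expected here, no change at the digits printed from compound 2 to compound 4 (within the scatter). Compound 4 is estimated at 94%, with a range from 84% to 100%.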

Compound 4, a percentage reported as activity, at one concentration (the size of the read-out at that concentration, not a potency): 105%
For compound 4 the middle estimate is 11 percentage points below the measured one, and the stated range ends below it.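

In this assay, methoxy in place of hydrogen on an aromatic carbon gives a modest step on one core, a number 11 percentage points higher from compound 2 to compound 4 (beyond the scatter), with the higher number standing for a weaker effect, while on the other core it gives no change at the digits printed from compound 1 to compound 3 (within the scatter). Set side by side, the two steps cannot be told apart: the same change on two cores in this assay, no change at the digits printed (within the scatter) from compound 1 to compound 3 and a number 11 percentage points higher (beyond the scatter) from compound 2 to compound 4, 11 percentage points apart, within the scatter of two such steps. This does not show that the change carries over unaltered from one core to the other, nor that the core alters its effect, and one step on each core supports no rule for the series.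

The compounds shown leave open whether a group other than methoxy, such as a fluorine atom, a carboxylic acid or a longer chain like ethoxy, would shift the number at the same aromatic carbon. Also open, as far as these compounds go, is how these steps would look at any concentration other than the single one tested, where the effect could be stronger or weaker.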